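A few compounds are considered here, and "the series" means these few. Any claim that something is new, unique, unknown or untested is made for them only; others in the source may bear on it.

Measured so far:
- compound 1, `CCOc1ccccc1C(=O)Nc1nc(-c2ccccc2)nc2c1nnn2Cc1ccccc1`: 1850 nM
- compound 2, `Nc1ccc(C(=O)Nc2nc(-c3ccccc3)nc3c2nnn3Cc2ccccc2)cc1`: 7.1 nM
- compound 3, `Nc1nc(-c2ccccc2)nc2c1nnn2Cc1ccccc1`: 5.6 nM

In an assay (strain Wistar) for displacement of a labelled ligand from adenosine receptor A1 (Rattus norvegicus), read by scintillation counting (a lower number here means a stronger inhibitor, a higher number a weaker inhibitor), compound 1 holds the highest of the three numbers. Its nearest neighbour is compound 2, reached by a 260-fold lower number from compound 1 to compound 2 (2.42 log units; beyond the scatter), and the furthest is compound 3, reached by a 330-fold lower number from compound 1 to compound 3 (2.52 log units; beyond the scatter). Compound 2 and compound 3 sit close together, a 1.3-fold lower number from compound 2 to compound 3 (0.10 log units; within the scatter), so the two measured changes at the amide-type nitrogen lead to much the same place.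

Compound 4, `O=C(Nc1nc(-c2ccccc2)nc2c1nnn2Cc1ccccc1)C1CC1`, is not yet measured in this assay. It differs from compound 1 in one place: cyclopropyl in place of 2-ethoxyphenyl on a carbonyl carbon. Among the compounds with values here, the change keeps a carbonyl on the nitrogen on the aromatic ring, as in compound 2, while taking away the 2-ethoxyphenyl, the one group tied to the high number of compound 1. Both measured steps at this position, from compound 1 to compound 2 and from compound 1 to compound 3, are large and in the same direction. Within the data shown here, a large step down is therefore expected for compound 4 in this assay, though its size is uncertain, since no step with cyclopropyl is known.

Compound 4 is estimated at 15 nM, with a range from 4 nM to 60 nM. This estimate means a step of a 120-fold lower number from compound 1 to compound 4 (2.09 log units; beyond the scatter).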

Compound 4, inhibition constant: 7.5 nM
The estimate for compound 4 lay 2.0-fold (0.30 log units) above the measured number; the range from low to high includes it.
By their numbers in this assay, from the lowest: compounds 3, 2 and 4 (each within the scatter of the next); then compound 1.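

In this assay, cyclopropyl on the carbonyl carbon gives a 250-fold lower number from compound 1 to compound 4 (2.39 log units; beyond the scatter), so a second acyl group, this one with a small non-aromatic ring in place of an aromatic one, also stands far from compound 1 while keeping the carbonyl on the amide-type nitrogen. The other two new steps, a 1.3-fold higher number from compound 3 to compound 4 (0.13 log units; within the scatter) and a 1.1-fold higher number from compound 2 to compound 4 (0.02 log units; within the scatter), both lie within the scatter, so hydrogen, (4-aminophenyl)carbonyl and cyclopropylcarbonyl on this nitrogen cannot be told apart in this assay, and among the four compounds only the (2-ethoxyphenyl)carbonyl of compound 1 goes against this flat reading. No measurement at hand explains why that one group stands apart from the other three.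

Going by these compounds, it remains open whether the high number of compound 1 belongs to the ethoxy group or to the phenyl ring that carries it, a question that a plain phenyl or a methoxyphenyl on the carbonyl carbon would help to settle. Also open, on these data alone, is how a longer alkyl chain, a tertiary amine or a carboxylic acid on the same carbonyl carbon would read against the three close compounds.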